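Swapping chloro for trifluoromethyl on the fused ring

This account rests on a few compounds, and the source may have more. Where it says the series, first, only, none or still open, it means among the compounds named here.

Of the compounds shown here, two have a number so far in a functional assay on MDA-MB-468 cells (Homo sapiens) for cytotoxicity, read by sulforhodamine B assay, with a stated time of 48 h; on this read-out lower numbers stand for stronger inhibition of growth and higher numbers for weaker inhibition of growth. Compound 1 `NC(=S)N/N=C1/C(=O)N(CN2CCN(c3ccnc4cc(Cl)ccc34)CC2)c2cccc(Cl)c21` gives 57600 nM in this assay, the highest of the two numbers. Among the compounds with values here, compound 2 `NC(=S)N/N=C1/C(=O)N(CN2CCN(c3ccnc4cc(Cl)ccc34)CC2)c2ccccc21` gives 20600 nM, and the only measured step, a 2.8-fold lower number from compound 1 to compound 2 (0.45 log units; beyond the scatter), is a modest one that comes from hydrogen in place of chloro on an aromatic carbon.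

Compound 3 `NC(=S)N/N=C1/C(=O)N(CN2CCN(c3ccnc4cc(C(F)(F)F)ccc34)CC2)c2cccc(Cl)c21` is not yet measured. It differs from compound 1 by trifluoromethyl in place of chloro on an aromatic carbon of a six-membered aromatic ring of carbon only, part of a fused or bridged system of two rings. Within the data shown here, no measured step touches this position or this exchange; the one measured step alters a different aromatic carbon and removes a chloro instead of exchanging it, so it gives only a loose sense of how much a single change of this sort can move this assay.

Among the measured compounds shown here, with no direct precedent, compound 3 is expected to stay close to compound 1, a step of a 1.2-fold lower number from compound 1 to compound 3 (0.06 log units; within the scatter) in this assay. The estimated value for compound 3 is 50000 nM, with a likely range from 15000 nM to 150000 nM.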

Compound 3, concentration for 50% growth inhibition: 23000 nM
Beside the measured number, compound 3's estimate is 2.2-fold (0.34 log units) above it, within the range that was stated.
By their numbers in this assay, from the lowest: compounds 2 and 3 (each within the scatter of the next); then compound 1.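

In this assay, trifluoromethyl in place of chloro, on an aromatic carbon of a six-membered aromatic ring of carbon only, part of a fused or bridged system of two rings, gives a 2.5-fold lower number from compound 1 to compound 3 (0.40 log units; beyond the scatter), so the number responds to what sits on this carbon. Within the data shown here, until now, the only measured change was hydrogen in place of the other chloro, which gave a 2.8-fold lower number from compound 1 to compound 2 (0.45 log units; beyond the scatter); there are now two separate places where a single change to compound 1 moves the number beyond the scatter, and in both the number falls. Nothing measured here bears on why the number moved at this position.

Left open is how hydrogen, a methoxy group or an amine would behave on this same carbon, since a single exchange cannot show a trend across groups. Also open, on these data alone, is whether the two changes would add up in one compound, with trifluoromethyl on this carbon and hydrogen in place of the other chloro.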